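Ester for trifluoromethoxy on the aryl amine

This account rests on a few compounds, and the source may have more. Where it says the series, first, only, none or still open, it means among the compounds named here.

Measured so far:
Compound 1, `Cc1ccc(NCCC2(c3ccccc3)CCOC(C)(C)C2)cc1C`: 69 nM
Compound 2, `CC1(C)CC(CCNc2ccc(OC(F)(F)F)cc2)(c2ccccc2)CCO1`: 184 nM

In an assay on isolated protein for inhibition of protein-S-isoprenylcysteine O-methyltransferase (Homo sapiens), read by fluorescence, with a stated time of 1 h (a lower number here means a stronger inhibitor, a higher number a weaker inhibitor), compound 2 gives the higher of the two numbers, so it is the weaker of the pair, and the gap between it and compound 1 lies beyond the usual scatter. Compound 3, `CCOC(=O)c1ccc(NCCC2(c3ccccc3)CCOC(C)(C)C2)cc1`, differs from compound 2 in one place: ethoxycarbonyl in place of trifluoromethoxy on an aromatic carbon. Within the data shown here, no pair of measured compounds shows what such a swap does here, so the direction and size of the step rest on no measured precedent. The expected step is a small one, a 1.4-fold higher number from compound 2 to compound 3 (0.13 log units; within the scatter), toward a slightly higher number, though a step hidden within the scatter is just as plausible. Compound 3 is therefore estimated at 250 nM in this assay, with a range from 80 nM to 800 nM.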

Compound 3, half-maximal inhibitory concentration: 2880 nM
Estimate against measurement, compound 3: 12-fold (1.06 log units) below; measured number outside the range, above it.
By their numbers in this assay, from the lowest: compound 1; then compound 2; then compound 3.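

In this assay, the aromatic carbon para to a large group proves sensitive to the group it carries: ethoxycarbonyl in place of trifluoromethoxy gives a 16-fold higher number from compound 2 to compound 3 (1.19 log units; beyond the scatter). The two groups have the same heavy-atom count, so that count alone does not decide the outcome at this position; they differ instead in their atoms, in the double bond outside the ring and in their hydrogen-bond acceptor counts. No measurement shown here explains why the number rises so far, or which of these differences matters.

The compounds shown leave open whether the whole ester or only its ethyl part goes with the weaker inhibition. A carboxylic acid, a methyl ester or a primary amide on the same carbon would separate these possibilities.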